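Sulfonyl aryl substitution notes toward compound 4

The source may report more compounds than this note shows. Statements on the series, on what has been measured and on what is new or still open speak of the compounds shown alone.

Measured in an assay on brain for displacement of a labelled ligand from 5-hydroxytryptamine receptor 4 (Cavia porcellus), with a stated time of 30 min, in the presence of a further agent that is not named here; on this read-out higher numbers stand for weaker inhibition and lower numbers for stronger inhibition:
Compound 1 `COc1ccc(S(=O)(=O)NCCN2CCC(CCC(=O)c3cc(Cl)c(N)cc3OC)CC2)cc1Br` gives 24.3 nM.
Compound 2 `COc1ccc(S(=O)(=O)NCCN2CCC(CCC(=O)c3cc(Cl)c(N)cc3OC)CC2)cc1` gives 12.3 nM.
Compound 3 `COc1cc(N)c(Cl)cc1C(=O)CCC1CCN(CCNS(=O)(=O)c2ccc(OC)c(N3CCN(C)CC3)c2)CC1` gives 3.46 nM.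

Compound 2 holds the second highest of the three numbers in this assay . Its nearest neighbour is compound 1, the step of a 2.0-fold lower number from compound 1 to compound 2 (0.30 log units; within the scatter) lying within the scatter; its furthest is compound 3, the step of a 3.6-fold lower number from compound 2 to compound 3 (0.55 log units; beyond the scatter) lying beyond it, as does a 7.0-fold lower number from compound 1 to compound 3 (0.85 log units; beyond the scatter).

Compound 4 `COc1cc(N)c(Cl)cc1C(=O)CCC1CCN(CCNS(=O)(=O)c2ccc(N)cc2)CC1` differs from compound 2 by amino in place of methoxy on an aromatic carbon. Among the measured compounds shown here, none of the measured steps touches this position: all three vary the neighbouring aromatic carbon, and the methoxy now replaced has been constant throughout. The measured steps at that other carbon range from within the scatter to modest, so no strong movement in this assay is expected from a single small swap here either. Compound 4 is therefore expected near compound 2, with the step of a 1.2-fold higher number from compound 2 to compound 4 (0.09 log units; within the scatter) estimated to stay within or just beyond the scatter. The estimate for compound 4 is 15 nM, in the range 5 nM to 45 nM.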

Compound 4, inhibition constant: 1.97 nM
Estimate against measurement, compound 4: 7.6-fold (0.88 log units) above; measured number outside the range, below it.
By their numbers in this assay, from the lowest: compounds 4 and 3 (each within the scatter of the next); then compounds 2 and 1 (each within the scatter of the next).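

In this assay, among the compounds shown here, amino in place of methoxy gives a 6.2-fold lower number from compound 2 to compound 4 (0.80 log units; beyond the scatter), so the aromatic carbon para to a large group, constant in the earlier compounds, is itself a place where this read-out moves. Counted from the 3-bromo-4-methoxyphenyl group, the change to 4-aminophenyl on the sulfonyl sulfur gives a 12-fold lower number from compound 1 to compound 4 (1.09 log units; beyond the scatter), the only step of this series so far marked as large. No accompanying data bear on the origin of the 4-methoxyphenyl to 4-aminophenyl step, which stands here as an observation only.

Going by these compounds, whether the amino group itself is needed at this carbon remains open, and a methylamino, dimethylamino, hydroxyl or acetamido group there would test this. Also open, on these data alone, is how amino at this carbon combines with 4-methylpiperazin-1-yl on the other aromatic carbon.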